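Fluoro for methyl on the aryl ring of compound 3

The compounds below may be only part of what the source reports. "The series", "measured", "known", "first", "only" and "open" are said of these compounds alone.

Measured compounds:
compound 1 `CN(C)c1ccc2c(=O)c(C(=O)Nc3cc(F)cc(F)c3)cn(-c3ccc(OCCCCCCC[N+]45CCN(CC4)CC5)cc3F)c2n1`: 42.4%
compound 2 `Cc1cc(OCCCCCCC[N+]2(C)CCCC2)ccc1-n1cc(C(=O)Nc2cc(F)cc(F)c2)c(=O)c2ccc(N(C)C)nc21`: "not active" (no number reported)
compound 3 `Cc1cc(OCCCCCCC[N+]2(C)CCCCC2)ccc1-n1cc(C(=O)Nc2cc(F)cc(F)c2)c(=O)c2ccc(N(C)C)nc21`: "not active" (no number reported)

The account follows compound 3 toward compound 4 `CN(C)c1ccc2c(=O)c(C(=O)Nc3cc(F)cc(F)c3)cn(-c3ccc(OCCCCCCC[N+]4(C)CCCCC4)cc3F)c2n1`. In an assay on LX2 cells for inhibition of COL1A1 promoter (Homo sapiens), read by a luciferase reporter, with a stated time of 24 h, tested at 50 uM (on this read-out higher numbers stand for a stronger effect at the one concentration tested and lower numbers for a weaker effect), compound 3 is reported as "not active" (no number reported), with no number given, and compound 2 stands the same way in this assay, reported as "not active" (no number reported). Only compound 1 carries a number in this assay, giving 42.4%, and compound 1 differs from compound 4 elsewhere in the structure as well, so no single step can be read off from it.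

The change from compound 3 to compound 4 is fluoro in place of methyl on an aromatic carbon. For the measured compounds named here, no step between measured compounds is available for this change, so the expected size rests only on the spread of the three compounds: compound 3 without a number, compound 1 with a modest value. A rise in this assay for compound 4 beyond the scatter is plausible but uncertain, and a further report without a number is possible.

For compound 4 in this assay the expected value is 25%, with a range from 0% to 50%.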

Compound 4, a percentage reported as inhibition, at one concentration (the size of the read-out at that concentration, not a potency): "not active" (no number reported)
Nothing numeric was reported for compound 4; the estimate stays without a comparison.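

In this assay, compound 3 and compound 4 both stand without a number, so no step can be read for fluoro in place of methyl. Nothing shown here offers an explanation for this result. The compounds shown leave open whether this exchange changes the read-out at all.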